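This account rests on a few compounds, and the source may have more. Where it says the series, first, only, none or still open, it means among the compounds named here.

Compound 1 `c1ccc(-c2cccc3c2CCC3c2ncc[nH]2)nc1` gives > 10000 nM in a functional assay on CHO cells for agonist activity at Alpha-1D adrenergic receptor (Homo sapiens), read by FLIPR and calcium flux; a lower number here means that less compound is needed, a higher number that more compound is needed for the effect. Compound 2 `COc1c(C)ccc2c1CCC2c1ncc[nH]1` gives > 10000 nM in this assay. Compound 3 `CCCS(=O)(=O)Nc1cccc2c1CCC2c1ncc[nH]1` gives > 10000 nM in this assay.

Each of these three values is a limit of the assay and not a measured number: the compound showed no effect up to the highest concentration tested. Compound 3 therefore stands at the limit of > 10000 nM in this assay, at which 3 of the 3 values shown sit, and so do the other two compounds, so none of the three can be ranked against the others. Among the measured compounds shown here, the single step that can be traced, a step that the two limits leave unreadable from compound 1 to compound 3, runs between two limits and gives no readable size or direction.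

Compound 4 `Cn1ccc(-c2cccc3c2CCC3c2ncc[nH]2)n1` differs from compound 3 by 1-methyl-1H-pyrazol-3-yl in place of (propylsulfonyl)amino on an aromatic carbon. For the measured compounds named here, compound 1 carries a pyridin-2-yl group at the same place and also sits at the limit, so the one comparison that touches the same position, compound 1 against compound 3, offers no readable step to build on. With nothing measured beyond the limit, compound 4 is expected to remain there as well, and the step that the limit leaves unreadable from compound 3 to compound 4 is expected to be one that the limits leave unreadable. The estimate for compound 4 in this assay is 15000 nM, with a range from 3000 nM to 60000 nM, and most likely the assay will again report only a limit.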

Compound 4, half-maximal effective concentration: > 10000 nM
Compound 4: no number, only a limit; the forecaster's own chance of this, stated with the estimate: 75%; the middle value does not contradict the limit.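

In this assay compound 4 gives > 10000 nM, which is a limit and not a number. The steps from compound 1 and from compound 3 to compound 4 run between limits and cannot be read. All the compounds shown share one position: the limit of > 10000 nM in this assay, at which 4 of the 4 values shown sit.

The compounds shown leave open which group on the shared core, if any, would give a measurable value in this assay.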